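Shortening the amine substituent on the shared core

The source may report more compounds than this note shows. Statements on the series, on what has been measured and on what is new or still open speak of the compounds shown alone.

Measured compounds:
- Compound 1, `Cc1onc(NS(=O)(=O)c2cccc3c(N(C)C)cccc23)c1C`: 60 nM
- Compound 2, `Cc1noc(NS(=O)(=O)c2cccc3c(NCCCCCc4ccccc4)cccc23)c1C`: 3050 nM
- Compound 3, `Cc1noc(NS(=O)(=O)c2ccc3cc(N)ccc3c2)c1C`: 660 nM

All three were tested in an assay on VSM-A10 cells for antagonist activity at Endothelin-1 receptor (Rattus norvegicus); on this read-out higher numbers stand for weaker inhibition and lower numbers for stronger inhibition. Among them, compound 2 gives the highest number, 3050 nM, so it is the weakest inhibitor of the set; its gap to compound 3 and its much larger gap to compound 1 both lie beyond the scatter of repeated measurements. Compound 1, which carries a small dimethylamino group on the shared core, gives 60 nM.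

Compound 4, `Cc1noc(NS(=O)(=O)c2cccc3c(NC(C)C)cccc23)c1C`, has not yet been measured in this assay. It differs from compound 2 in one place: isopropyl in place of 5-phenylpentyl on a nitrogen on an aromatic ring. The long chain with its phenyl ring is replaced by a short branched alkyl group, bringing the structure closer to that of compound 1.

Given that compound 1, with its small amine substituent, gives 60 nM, a sizeable decrease in the number is expected from compound 2 to compound 4, a 15-fold lower number from compound 2 to compound 4 (1.18 log units; beyond the scatter), well beyond the scatter. Compound 4 is therefore estimated at 200 nM, with a range from 50 nM to 800 nM.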

Compound 4, half-maximal inhibitory concentration: 20 nM
Compound 4: the middle estimate sits 10-fold (1.00 log units) above what was measured, outside the stated range (below it).
By their numbers in this assay, from the lowest: compound 4; then compound 1; then compound 3; then compound 2.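

In this assay, among these compounds, isopropyl in place of 5-phenylpentyl on the nitrogen gives a 150-fold lower number from compound 2 to compound 4 (2.18 log units; beyond the scatter), the first comparison in this set that changes only this group, and it shows that inhibition depends strongly on what this nitrogen carries. With compound 4 at 20 nM, neither the long chain nor its phenyl ring is needed for strong inhibition on this core. Nothing measured here explains why the step is so large.

This single step changes chain length and removes the phenyl ring together, so the two changes cannot be told apart. A plain pentyl chain on the same nitrogen would separate them, while a benzyl or a cyclopropyl group would show how much room for change this position allows.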